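Ethyl to hydroxy on the shared core

The source may report more compounds than this note shows. Statements on the series, on what has been measured and on what is new or still open speak of the compounds shown alone.

compound 1 `Nc1c(F)c(N2CCC(N)C2)cc2c1c(=O)c(C(=O)O)cn2C1CC1`: 54 ug/mL
compound 2 `CCc1c(F)c(N2CCC(N)C2)cc2c1c(=O)c(C(=O)O)cn2C1CC1`: 46 ug/mL

In a functional assay on V79 cells (Cricetulus griseus) for cytotoxicity, read by colony formation (on this read-out higher numbers stand for weaker inhibition and lower numbers for stronger inhibition), compound 2 at 46 ug/mL stands within the scatter of compound 1 at 54 ug/mL and has no separate rank. Compound 3 `NC1CCN(c2cc3c(c(O)c2F)c(=O)c(C(=O)O)cn3C2CC2)C1` brings hydroxy in place of ethyl on an aromatic carbon as hydroxy in place of ethyl on an aromatic carbon. For the measured compounds named here, the only measured step that bears on this, ethyl in place of amino on an aromatic carbon, is a 1.2-fold lower number from compound 1 to compound 2 (0.07 log units; within the scatter) and no measured compound yet carries hydroxy. No step beyond the scatter is therefore expected in this assay and the range is kept wide. The expected step is a 1.0-fold lower number from compound 2 to compound 3 (0.01 log units; within the scatter) as estimated here. For compound 3 the estimated value is 45 ug/mL with an expected range from 18 ug/mL to 100 ug/mL in this read-out.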

Compound 3, half-maximal inhibitory concentration: 72 ug/mL
The estimate for compound 3 lay 1.6-fold (0.20 log units) below the measured number, and the stated range covers the measured number.
By their numbers in this assay, from the lowest: compounds 2, 1 and 3 (each within the scatter of the next).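

Hydroxy in place of ethyl on this aromatic carbon (a 1.6-fold higher number from compound 2 to compound 3 (0.19 log units; within the scatter)) and hydroxy in place of amino (a 1.3-fold higher number from compound 1 to compound 3 (0.12 log units; within the scatter)) both stay within the scatter in this assay. The position has now carried ethyl, amino and hydroxy without a step beyond the scatter, including on the change from ethyl, with no hydrogen-bond donor or acceptor, to hydroxy, with one of each. Nothing available explains this result.

On these data alone, whether a longer alkyl chain, a methoxy group or a carboxylic acid at this carbon would give a step beyond the scatter remains open. As far as these compounds go, whether the same flat picture holds with a different amine in place of the 3-aminopyrrolidin-1-yl group also remains open.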